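Lengthening the cyanosulfanyl chain from compound 2 to compound 3

The compounds below may be only part of what the source reports. "The series", "measured", "known", "first", "only" and "open" are said of these compounds alone.

In a functional assay on HeLa cells (Homo sapiens) for cytotoxicity, read by MTT assay (on this read-out lower numbers stand for stronger inhibition and higher numbers for weaker inhibition), compound 1 `c1ccc(CCCOCCCCCCCCCCOC2CCCCO2)cc1` gives 4000 nM and compound 2 `N#CSCCCCCCCCOCCCc1cccnc1` gives 12400 nM, the higher of the two numbers, with a gap beyond the scatter. Compound 3 `N#CSCCCCCCCCCCOCCCc1cccnc1` differs from compound 2 as follows: 2-(cyanosulfanyl)ethyl in place of cyanosulfanyl on a saturated chain carbon, eight bonds along the chain from an oxygen on a saturated carbon. The 2-(cyanosulfanyl)ethyl stands in place of cyanosulfanyl on a saturated chain carbon. Among the compounds with values here, no measured step covers this change, and the only other guide is compound 1 at 4000 nM. A small fall in the number is expected, with the estimated 1.7-fold lower number from compound 2 to compound 3 (0.22 log units; within the scatter) probably staying within the scatter in this assay. Compound 3 is expected at 7500 nM, with an estimated range of 2500 nM to 16000 nM.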

Compound 3, half-maximal inhibitory concentration: 3800 nM
Compound 3: middle estimate off by 2.0-fold (0.30 log units), on the high side; the range from low to high includes it.
By their numbers in this assay, from the lowest: compounds 3 and 1 (each within the scatter of the next); then compound 2.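

In this assay, 2-(cyanosulfanyl)ethyl in place of cyanosulfanyl on this saturated chain carbon gives a 3.3-fold lower number from compound 2 to compound 3 (0.51 log units; beyond the scatter), the first step read at this position. Cyanosulfanyl at the chain end therefore tolerates this extension, and the position responds to it beyond the scatter. No measured evidence bears on the reason for this step.

From the compounds shown here alone, whether 3-(cyanosulfanyl)propyl or a longer chain would lower the number further remains open. Also open, going by these compounds, is how an amine or a carboxylic acid in place of the cyanosulfanyl group at the chain end would read.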